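Extending compound 1 with a methylpyrazole ring

The compounds below may be only part of what the source reports. "The series", "measured", "known", "first", "only" and "open" are said of these compounds alone.

Compound 1 `COc1cc(-c2ccnc3cc(-c4ccc(Cl)cc4)nn23)cc(OC)c1OC` gives 2320 nM in a functional assay on MCF7 cells (Homo sapiens) for inhibition, read by CCK-8 assay, with a stated time of 48 h (on this read-out lower numbers stand for stronger inhibition and higher numbers for weaker inhibition), the highest of the three measured numbers. Compound 2 `COc1cc(-c2ccnc3cc(-c4ccc5cc[nH]c5c4)nn23)cc(OC)c1OC` gives 23 nM and compound 3 `COc1cc(-c2ccnc3cc(-c4c[nH]c5ccccc45)nn23)cc(OC)c1OC` gives 85 nM in this assay. Compound 4 `COc1cc(-c2ccnc3cc(-c4ccc(-c5cnn(C)c5)cc4)nn23)cc(OC)c1OC` differs from compound 1 by 1-methyl-1H-pyrazol-4-yl in place of chloro on an aromatic carbon. Within the data shown here, no measured step changes the chloro alone; the steps that come nearest, a 100-fold lower number from compound 1 to compound 2 (2.00 log units; beyond the scatter) and a 27-fold lower number from compound 1 to compound 3 (1.44 log units; beyond the scatter), replace the whole 4-chlorophenyl with a bicyclic heteroaromatic group, and both are large. Because compound 1 stands at 2320 nM, an added heteroaromatic ring is expected to bring a clearly lower number, though a smaller step than those two. The estimate is a 4.6-fold lower number from compound 1 to compound 4 (0.67 log units; beyond the scatter), giving compound 4 an expected value of 500 nM with a range from 150 nM to 2500 nM.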

Compound 4, half-maximal inhibitory concentration: 274 nM
The estimate for compound 4 lay 1.8-fold (0.26 log units) above the measured number, within the range that was stated.
By their numbers in this assay, from the lowest: compound 2; then compound 3; then compound 4; then compound 1.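

The step of an 8.5-fold lower number from compound 1 to compound 4 (0.93 log units; beyond the scatter) shows that in this assay the number responds to a change at the chloro alone, on an aromatic carbon para to a large group. The earlier steps shown here replaced the whole 4-chlorophenyl, whereas here the six-membered ring stays and 1-methyl-1H-pyrazol-4-yl takes the place of chloro. Nothing available explains this step. The compounds shown leave open whether the methyl on the pyrazole contributes to the step, and whether a morpholine or a dimethylamino group at this place would shift the number similarly.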